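Tolerance notes on the step to compound 4

The source may hold more compounds than are shown below. What is called first, only, known or untested is meant among the compounds shown, and "the series" means these compounds.

In an ADME assay on HEK293 cells (Homo sapiens) for cytotoxicity, read by resazurin assay, with a stated time of 48 h (a higher number here means that more compound is tolerated, a lower number that less compound is tolerated), compound 1 `O=S(=O)(Nc1ccc(-c2nc3ccccc3o2)cc1)c1cccc(O)c1` gives > 100000 nM, which is a limit of the assay. Compound 2 `COc1ccccc1S(=O)(=O)Nc1ccc(-c2nc3ccccc3o2)cc1` gives > 100000 nM, also a limit of the assay. Going by the values given here, compound 3 `O=S(=O)(Nc1ccc(-c2nc3ccccc3o2)cc1)c1ccc(C(F)(F)F)cc1` gives 94000 nM, the only actual number so far. The rest of the picture is the limit of > 100000 nM in this assay, at which 2 of the 3 values shown sit.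

Compound 4 `O=S(=O)(Nc1ccc(-c2nc3ccccc3o2)cc1)c1ccc(Cl)cc1` has chloro in place of trifluoromethyl on an aromatic carbon, para to a large group: chloro in place of trifluoromethyl on an aromatic carbon.

Among the compounds with values here, the only measured step is a step that the two limits leave unreadable from compound 1 to compound 2. It concerns a different change and offers no size to carry over, so the expectation rests on compound 3 at 94000 nM alone. No shift in either direction beyond the scatter is expected in this assay, and the estimated 1.0-fold lower number from compound 3 to compound 4 (0.02 log units; within the scatter) reflects that. The assay may well report only a limit for this compound. For compound 4 the estimated value is 90000 nM, with an expected range from 45000 nM to 150000 nM.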

Compound 4, half-maximal cytotoxic concentration: > 100000 nM
Compound 4: a limit, no number; the forecaster's own chance of this, stated with the estimate: 40%; middle value at least 1.1-fold (0.04 log units) from the limit.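

In this assay, chloro in place of trifluoromethyl on an aromatic carbon, para to a large group, gives an at least 1.0-fold higher number from compound 3 to compound 4 (0.02 log units; that floor lies within the scatter). Compound 4 reads only as a limit, so this step has a floor and no size, and at this position the change shows no loss of tolerance beyond the scatter. The steps to compound 4 from compound 1 and from compound 2 cannot be read, and the series now sits mostly at one edge of the assay: the limit of > 100000 nM in this assay, at which 3 of the 4 values shown sit.

As far as these compounds go, how far the true values of compound 1, compound 2 and compound 4 lie past that limit remains open, and so does their order among themselves. Also open, from the compounds shown here alone, is whether an amine or a carboxylic acid at this position would give an actual number in this assay.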